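The source may report more compounds than this note shows. Statements on the series, on what has been measured and on what is new or still open speak of the compounds shown alone.

Compound 1 `CN1CCN(c2nc(N)nc(COc3ccccc3Cl)n2)CC1` gives 129 nM in an assay on HEK293 cells for displacement of a labelled ligand from 5-hydroxytryptamine receptor 6 (Homo sapiens), read by radioligand binding, with a stated time of 1 h; a lower number here means a stronger inhibitor, a higher number a weaker inhibitor.
Compound 2 `CN1CCN(c2nc(N)nc(COc3cccc(Cl)c3)n2)CC1` gives 148 nM in this assay.
Compound 3 `Cc1cc(Cl)ccc1OCc1nc(N)nc(N2CCN(C)CC2)n1` gives 911 nM in this assay.

Compound 3 stands highest of these three numbers, that is, as the weakest inhibitor of the set. Its distance to the other two is beyond the scatter: a 7.1-fold higher number from compound 1 to compound 3 (0.85 log units; beyond the scatter) and a 6.2-fold higher number from compound 2 to compound 3 (0.79 log units; beyond the scatter). Compound 1 and compound 2, by contrast, sit within the scatter of each other, a 1.1-fold higher number from compound 1 to compound 2 (0.06 log units; within the scatter), so no order between them can be read.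

Compound 4 `CN1CCN(c2nc(N)nc(COc3ccc(Cl)cc3Cl)n2)CC1` differs from compound 3 in one place: chloro in place of methyl on an aromatic carbon. The chloro that compound 3 already carries stays; only the methyl is exchanged. For the measured compounds named here, no measured step swaps a methyl for a chloro, so the change can only be judged indirectly. The two steps that bear on it are those into compound 3, a 7.1-fold higher number from compound 1 to compound 3 (0.85 log units; beyond the scatter) and a 6.2-fold higher number from compound 2 to compound 3 (0.79 log units; beyond the scatter), both modest and both in the weakening direction; compound 1 shows that a single chloro in the position ortho to the large group is compatible with a low number. Compound 4 is therefore expected to land between compound 3 and compound 1, with a 2.0-fold lower number from compound 3 to compound 4 (0.31 log units; beyond the scatter) as the estimated step. The estimate for compound 4 in this assay is 450 nM, with a range from 130 nM to 1500 nM.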

Compound 4, inhibition constant: 128 nM
Estimate against measurement, compound 4: 3.5-fold (0.55 log units) above; measured number outside the range, below it.
By their numbers in this assay, from the lowest: compounds 4, 1 and 2 (each within the scatter of the next); then compound 3.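

In this assay, exchanging the methyl for a chloro at the position ortho to a large group, with the other chloro kept, gives (a 7.1-fold lower number from compound 3 to compound 4 (0.85 log units; beyond the scatter)), so the weak result of compound 3 is tied to that methyl, not to the chloro the two compounds share. The 2,4-dichlorophenyl group also shows that a second chloro on the ring can be carried with no readable change from a single chloro, both against the 2-chlorophenyl group (a 1.0-fold lower number from compound 1 to compound 4 (0.00 log units; within the scatter)) and against the 3-chlorophenyl group (a 1.2-fold lower number from compound 2 to compound 4 (0.06 log units; within the scatter)). Nothing in the data shown explains why a methyl and a chloro part ways at this position.

It remains open whether the methyl costs as much without the other chloro, since a plain 2-methylphenyl group does not appear among these compounds. Also open, going by these compounds, is how other groups at the same position would read, such as a fluoro, a bromo, a methoxy or a nitrile, and so whether the chloro is a special case or one of many groups accepted there.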